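This account rests on a few compounds, and the source may have more. Where it says the series, first, only, none or still open, it means among the compounds named here.

Of the compounds shown here, two of a shared core have been measured so far. Compound 1 `O=C(Nc1nn(-c2ccccc2)c(=O)c2ccccc12)c1ccccc1` carries a benzamide on the core and gives, in an assay on CHO cells for displacement of a labelled ligand from adenosine receptor A3 (Homo sapiens) (a lower number here means a stronger inhibitor, a higher number a weaker inhibitor), a value of 1100 nM. Compound 2 `COc1ccccc1NC(=O)Nc1nn(-c2ccccc2)c(=O)c2ccccc12` replaces that benzamide with a urea bearing a 2-methoxyphenyl group, and in this assay compound 2 gives 8.9 nM. That single exchange produced a 120-fold lower number from compound 1 to compound 2 (2.09 log units; beyond the scatter). Among the two numbers known, compound 2 stands at the lower end; the only other value, that of compound 1, is far higher.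

Compound 3 `COc1ccccc1CNC(=O)Nc1nn(-c2ccccc2)c(=O)c2ccccc12` keeps the urea of compound 2 but inserts one carbon between the nitrogen and the ring: 2-methoxybenzyl in place of 2-methoxyphenyl on an amide-type nitrogen. Within the data shown here, no measured step addresses such a lengthening; the one step known concerns the change from a benzamide to an aryl urea, not the distance of the ring from the urea nitrogen. With the ring moved outward, the expectation is a moderate loss in this assay, worded as a 3.9-fold higher number from compound 2 to compound 3 (0.59 log units; beyond the scatter). Compound 3 is therefore expected to show 35 nM, with a range from 6 nM to 250 nM.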

Compound 3, inhibition constant: 274 nM
Estimate against measurement, compound 3: 7.8-fold (0.89 log units) below, outside the stated range (above it).
By their numbers in this assay, from the lowest: compound 2; then compound 3; then compound 1.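

On the amide-type nitrogen of the urea, the way the ring is attached matters greatly in this assay: 2-methoxybenzyl in place of 2-methoxyphenyl, 9 heavy atoms instead of 8 and the same ring and methoxy group, gives a large loss (a 31-fold higher number from compound 2 to compound 3 (1.49 log units; beyond the scatter)). The urea therefore does not carry the earlier gain (a 120-fold lower number from compound 1 to compound 2 (2.09 log units; beyond the scatter)) by itself, although compound 3 keeps a modest advantage over the benzamide (a 4.0-fold lower number from compound 1 to compound 3 (0.60 log units; beyond the scatter)), a step still beyond the usual scatter. Nothing available explains why this small change in the group on the nitrogen has so large an effect.

The compounds shown leave open whether the loss continues with a longer chain, such as 2-phenylethyl, or whether a urea with a plain methyl on this nitrogen would behave like either compound 2 or compound 3. Going by these compounds, every urea here also carries the methoxy group, so its part remains open, and only a urea bearing an unsubstituted phenyl or benzyl group, or one with chlorine in place of methoxy, could begin to separate it from the effect of the ring itself.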